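Working notes on the aryl substituent step

The source may hold more compounds than are shown below. What is called first, only, known or untested is meant among the compounds shown, and "the series" means these compounds.

Among the measured compounds shown here, compound 2 `Cc1ccc(N2CCn3c2n[nH]c(=O)c3=N)cc1` gives 37% in a functional assay on A549 cells (Homo sapiens) for antiproliferative activity, with a stated time of 72 h, tested at 10 ug/mL (a lower number here means a weaker effect, a higher number a stronger effect of the compound at the concentration tested), and holds the higher of the two numbers measured so far; the nearest is compound 1 `N=c1c(=O)[nH]nc2n1CCN2c1ccc(Cl)cc1`, which gives 25% in this assay. Compound 3 `N=c1c(=O)[nH]nc2n1CCN2c1ccccc1` is not yet measured. It differs from compound 2 as follows: hydrogen in place of methyl on an aromatic carbon. For the measured compounds named here, the one measured step is a number 12 percentage points higher from compound 1 to compound 2 (beyond the scatter), at the same aromatic carbon; it shows that exchanging the group at this carbon can move the read-out modestly, but no measured step exchanges methyl for hydrogen, so the direction is not fixed by the data. A small shift, if any, is expected, leaning downward: a number 7 percentage points lower from compound 2 to compound 3 (within the scatter). Compound 3 is therefore estimated at 30%, within a range of 15% to 45%.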

Compound 3, a percentage reported as inhibition, at one concentration (the size of the read-out at that concentration, not a potency): 7%
Compound 3: middle estimate off by 23 percentage points, on the high side, outside the stated range (below it).
By their numbers in this assay, from the lowest: compound 3; then compound 1; then compound 2.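

Hydrogen in place of methyl gives a number 30 percentage points lower from compound 2 to compound 3 (beyond the scatter), and hydrogen in place of chloro gives a number 18 percentage points lower from compound 1 to compound 3 (beyond the scatter). Both steps run the same way, so among these three compounds either substituent at this aromatic carbon reads higher than hydrogen, which the earlier exchange of chloro for methyl could not show, as it compared two substituents and had no unsubstituted reference. Nothing at hand accounts for why methyl and chloro both read higher than hydrogen.

As far as these compounds go, whether an amine, a methoxy group or a longer chain such as ethyl at this carbon would hold or raise the read-out remains open. Also open, from the compounds shown here alone, is whether this order of stronger and weaker effect, seen at a single concentration, would carry over to other concentrations.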